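The source may report more compounds than this note shows. Statements on the series, on what has been measured and on what is new or still open speak of the compounds shown alone.

Measured compounds in a physicochemical assay for solubility, read by chemiluminescence, measured as kinetic solubility; a lower number here means a less soluble compound, a higher number a more soluble compound:
- Compound 1 `COc1nn(CC(N)=O)c2ncnc(NS(=O)(=O)c3cccc(Cl)c3Cl)c12`: >= 490000 nM, a limit
- Compound 2 `COc1nn(C2COC2)c2ncnc(NS(=O)(=O)c3cccc(Cl)c3Cl)c12`: 142000 nM
- Compound 3 `COc1nn(C)c2nc(C)nc(NS(=O)(=O)c3cccc(Cl)c3Cl)c12`: >= 557000 nM, a limit

Compound 3 gives a limit of the assay, >= 557000 nM, and not a number. Compound 1 is likewise recorded only as a limit, >= 490000 nM. Compound 2, at 142000 nM, is the only one of the three with a plain number.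

Compound 4 `CCNc1nc(NS(=O)(=O)c2cccc(Cl)c2Cl)c2c(OC)nn(C)c2n1` has not yet been measured. It differs from compound 3 by one change: ethylamino in place of methyl on an aromatic carbon. In words, ethylamino stands in place of methyl on an aromatic carbon, between two ring nitrogen atoms.

Among the compounds with values here, only one measured step is available, an at least 3.4-fold lower number from compound 1 to compound 2 (0.53 log units; beyond the scatter). That step is a swap of oxetan-3-yl for carbamoylmethyl on an aromatic nitrogen, so it bears on the present change only indirectly. Within the data shown here, it shows that one substitution on the shared core can move the reading in this assay beyond the scatter, and no measured step tests the aromatic carbon concerned here. With compound 3 recorded only as a limit, a modest move to a lower number is the more likely outcome, though a second limit remains possible.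

The expected change is an at least 2.2-fold lower number from compound 3 to compound 4 (0.34 log units; beyond the scatter). For compound 4 the estimated value is 250000 nM, with an expected range from 70000 nM to 600000 nM.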

Compound 4, solubility: 219000 nM
Compound 4: middle estimate off by 1.1-fold (0.06 log units), on the high side, within the range that was stated.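

Within the data shown here, this is the first measured change at the aromatic carbon between two ring nitrogen atoms, and in this assay ethylamino in place of methyl gives an at least 2.5-fold lower number from compound 3 to compound 4 (0.40 log units; beyond the scatter). Among these compounds, the one earlier step concerned a group on an aromatic nitrogen, so this result shows that a change on the aromatic carbon can also move the reading beyond the scatter, and that compound 4 gives a plain number on this part of the scale. The size of the step remains a lower bound because compound 3 is recorded only as a limit: the limit of >= 557000 nM in this assay, at which 1 of the 4 values shown sits.

The compounds shown leave open whether the step goes with the nitrogen that enters or with the ethyl chain on it, a question that a plain amino group, a methylamino group or an ethyl group on this carbon would help to separate. They also leave open how a longer chain or a carboxylic acid on this carbon would read, and whether ethylamino gives a step of similar size with oxetan-3-yl or carbamoylmethyl on the aromatic nitrogen.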